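Rat microsomal clearance: pyrazolyl to methoxy

A few compounds are considered here, and "the series" means these few. Any claim that something is new, unique, unknown or untested is made for them only; others in the source may bear on it.

Measured so far in an ADME assay on microsomes from liver (Rattus norvegicus) for metabolic stability (a lower number here means slower removal, a higher number faster removal of the compound), are:
- compound 1 `CNc1nc(NC2(C#N)CCCCC2)nc(-n2cccn2)n1` at 103 mL/min/kg
- compound 2 `CCCC(C#N)(CCC)Nc1nc(NC)nc(-n2cncn2)n1` at 32 mL/min/kg
- compound 3 `CCC(C)(C#N)Nc1nc(NC)nc(-n2cncn2)n1` at 32 mL/min/kg

Compound 1 at 103 mL/min/kg is the highest of the three numbers, beyond the scatter from both of the others. For the measured compounds named here, compound 2 and compound 3 each differ from compound 1 in more than one place, so no measured step isolates the group in question.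

The next compound is compound 4 `CNc1nc(NC2(C#N)CCCCC2)nc(OC)n1` and its change is methoxy in place of 1H-pyrazol-1-yl on an aromatic carbon with the rest of compound 1 kept. Going by the values given here, the data hold no measured example of this replacement, so any expectation is weakly grounded. A modest downward lean rests only on compound 1 standing at 103 mL/min/kg at the top of the three numbers, while compound 3 at 32 mL/min/kg shows that much lower clearance occurs in this small set. The estimated move is a 1.5-fold lower number from compound 1 to compound 4 (0.17 log units; within the scatter) and it is expected to stay within the scatter, with a real chance of no change at all. Compound 4 is estimated at 70 mL/min/kg with an expected range from 33 mL/min/kg to 135 mL/min/kg in this assay when measured.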

Compound 4, clearance: 196 mL/min/kg
For compound 4 the middle estimate is 2.8-fold (0.45 log units) below the measured one, outside the stated range (above it).
By their numbers in this assay, from the lowest: compounds 2 and 3 (each within the scatter of the next); then compounds 1 and 4 (each within the scatter of the next).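

In this assay, for the compounds shown here, methoxy in place of 1H-pyrazol-1-yl on the aromatic carbon opposite the ring nitrogen gives a 1.9-fold higher number from compound 1 to compound 4 (0.28 log units; within the scatter), the first step that isolates this position. Within the scatter, the two compounds cannot be told apart, so this single pair shows that the five-membered aromatic ring and its two hetero atoms can give way to a group with no ring, with the rest of compound 1 kept, without a move that can be read in this assay. No measured information on the compounds explains this reading or links it to any property of either group.

Still open, from the compounds shown here alone, is whether any group at this position moves this assay beyond the scatter, for example an amine such as dimethylamino, or a longer alkoxy chain such as ethoxy. Going by these compounds alone, also open is whether methoxy in place of a ring at this position reads the same when the cyclohexyl nitrile part of compound 1 is replaced by an open chain, since no pair tests that.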